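Tolerated at the limit: two amides and a third

The source may report more compounds than this note shows. Statements on the series, on what has been measured and on what is new or still open speak of the compounds shown alone.

In a toxicity assay on THP-1 cells (Homo sapiens) for inhibition (a higher number here means that more compound is tolerated, a lower number that less compound is tolerated), compound 1 `COc1ccc(-c2cnc(NC(=O)c3cccc(OC)c3)n2C)cc1` gives > 100000 nM as a limit of the assay, not a number. Compound 2 `COc1ccc(C(=O)Nc2ncc(-c3ccc(OC)cc3)n2C)cc1` gives > 100000 nM as a limit too, so it has no exact value to start from. The whole record so far is the limit of > 100000 nM in this assay, at which 2 of the 2 values shown sit, and nothing more.

Compound 3 `COc1ccc(-c2cnc(NC(=O)c3ccccc3Cl)n2C)cc1` differs from compound 2 in one place, on a carbonyl carbon whose other neighbour is an amide-type nitrogen, where 2-chlorophenyl stands in place of 4-methoxyphenyl (2-chlorophenyl in place of 4-methoxyphenyl on a carbonyl carbon).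

Among the compounds with values here, the one measured step, a step that the two limits leave unreadable from compound 1 to compound 2, changes a group on that same kind of carbonyl carbon, yet it offers no size to carry over. With compound 1 and compound 2 both at a limit, nothing points in either direction, so no change beyond the scatter is expected in this assay. The expected step is a number no higher from compound 2 to compound 3 (the limit leaves the size open) and it is an estimate with no direction favoured. For compound 3 the estimate is 100000 nM with an expected range from 40000 nM to 200000 nM and quite possibly only a limit reported.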

Compound 3, half-maximal cytotoxic concentration: > 50000 nM
Compound 3: only a limit was reported (the forecaster's own chance of this, stated with the estimate: 85%); the middle value is on the limit's open side.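

Within the data shown here, compound 1, compound 2 and compound 3 all stand at limits of this assay and not at numbers, so no step among them can be read. The compounds shown leave open what concentration of any of them is cytotoxic, and whether changing the group on the carbonyl carbon alters that concentration at all.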